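Chloro for methoxy on the aryl of compound 1

The source may hold more compounds than are shown below. What is called first, only, known or untested is meant among the compounds shown, and "the series" means these compounds.

Within the data shown here, compound 1, with the structure `COc1ccccc1C1CCc2nc[nH]c2C1`, is the only member of this small set that gives a number in a functional assay on CHO cells for agonist activity at Alpha-1D adrenergic receptor (Homo sapiens), read by FLIPR and calcium flux; on this read-out lower numbers stand for an effect already at smaller amounts and higher numbers for an effect only at larger amounts of compound: compound 1 gives 3500 nM. The other two measured compounds reach only the limit of the assay. Compound 2, `c1ccc(C2CCc3nc[nH]c3C2)cc1`, gives > 10000 nM; > 10000 nM; > 10000 nM (3 entries) in this assay, a limit and not a number. Compound 3, `N#Cc1ccccc1C1Cc2nccn2C1`, gives > 10000 nM in this assay, again a limit. Compound 1 therefore stands alone with a measured value, and the limit itself is set out as the limit of > 10000 nM in this assay, at which 1 of the 3 values shown sits.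

Compound 4, `Clc1ccccc1C1CCc2nc[nH]c2C1`, differs from compound 1 in a single place: chloro in place of methoxy on an aromatic carbon. Among the measured compounds shown here, no pair of measured compounds differs in exactly this way, so no measured step speaks for the change directly. What the set shows is that a group on the six-membered aromatic ring of carbon only accompanies a measured number in compound 1, while the bare ring of compound 2 stays at the limit.

On that basis compound 4 is expected to land near compound 1, with a step of a 1.2-fold lower number from compound 1 to compound 4 (0.07 log units; within the scatter) that stays within the scatter. The estimate for compound 4 in this assay is 3000 nM, expected to fall between 800 nM and 12000 nM.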

Compound 4, half-maximal effective concentration: > 10000 nM
Compound 4 gave a limit, no number; the forecaster's own chance of this, stated with the estimate: 35%; middle value at least 3.3-fold (0.52 log units) away from the limit.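

In this assay, among these compounds, chloro in place of methoxy on this aromatic carbon gives an at least 2.8-fold higher number from compound 1 to compound 4 (0.45 log units; beyond the scatter), the first step at this position that can be read directly. Among the compounds shown here, the earlier compounds showed only that the bare ring of compound 2 stayed at the limit while compound 1, with its methoxy, gave a number, which left open whether any group at this place would be enough; compound 4 shows that at least one group, chloro, is not, so in this short series the number goes with methoxy and not with the mere presence of a group on the ring. Compound 4 now reaches a limit and gives no number, as compound 2 does, so the two can't be ordered against each other, and the read-out is bounded in the same way for both: the limit of > 10000 nM in this assay, at which 2 of the 4 values shown sit.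

Going by these compounds, whether ethoxy or a hydroxyl group at the same place would keep a number as methoxy does remains open, and so does whether the result depends on the oxygen or on the methyl of the methoxy group. Also open is how methoxy would behave on another aromatic carbon of the same ring, since the compounds shown carry it at one place only.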